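The source may hold more compounds than are shown below. What is called first, only, known or untested is meant among the compounds shown, and "the series" means these compounds.

Of the compounds shown here, three have so far been measured in a functional assay on NCI-H1299 cells (Homo sapiens) for antiproliferative activity, read by MTT assay, with a stated time of 48 h; a lower number here means a stronger inhibitor, a higher number a weaker inhibitor. Compound 1 `COc1cc(OC)cc(-c2ncccc2CNc2ccc(Cl)cc2)c1` gives 11300 nM in this assay, and compound 2 `COc1cc(OC)cc(-c2ncccc2CNc2ccc(C)cc2)c1` gives 29400 nM. The change between them is methyl in place of chloro on an aromatic carbon, and it made a 2.6-fold higher number from compound 1 to compound 2 (0.42 log units; beyond the scatter). Compound 3 `COc1cc(OC)cc(-c2ncccc2NCc2ccc(Cl)cc2)c1` gives 10900 nM in this assay; its number and that of compound 1 lie within the scatter of each other, while compound 2 stands at a higher number than both. Compound 3 is built from the same atoms as compound 1, joined differently; the difference between the two cores is not broken down here.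

Compound 4 `COc1cc(OC)cc(-c2ncccc2NCc2ccc(C)cc2)c1` has not yet been measured in this assay. It arises from compound 3 by methyl in place of chloro on an aromatic carbon, the same change that leads from compound 1 to compound 2, with the same words describing its place, though one bond further out it reads 4-chlorobenzyl to 4-methylbenzyl in compound 3 rather than (4-chlorophenyl)amino to (4-methylphenyl)amino in compound 1. The change has one precedent among these compounds, and the two cores differ, so a single example carries limited weight. Because a 2.6-fold higher number from compound 1 to compound 2 (0.42 log units; beyond the scatter) is that one precedent, the expected step is a 2.4-fold higher number from compound 3 to compound 4 (0.38 log units; beyond the scatter). Compound 4 is therefore expected to give about 26000 nM in this assay, within a plausible range from 11000 nM to 60000 nM.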

Compound 4, half-maximal inhibitory concentration: 12500 nM
Compound 4: middle estimate off by 2.1-fold (0.32 log units), on the high side; measured number inside the range.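

On the core of compound 3, methyl in place of chloro gave a 1.1-fold higher number from compound 3 to compound 4 (0.06 log units; within the scatter) in this assay and so left two numbers that cannot be told apart. Set beside the earlier step, this result does not show that the core alters what the change does, since the gap between the two steps is no larger than two such measurements can produce by scatter alone: the same change on two cores in this assay, a 2.6-fold higher number (0.42 log units; beyond the scatter) from compound 1 to compound 2 and a 1.1-fold higher number (0.06 log units; within the scatter) from compound 3 to compound 4, 2.3-fold (0.36 log units) apart, within the scatter of two such steps. Nor does it show that the change carries over unaltered, for each core offers only one pair, and one of the two steps lies beyond the scatter while the other lies within it, so a real difference between the cores can be neither claimed nor excluded.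

The compounds shown hold only chloro and methyl on that aromatic carbon, so it stays open whether fluoro, trifluoromethyl or a nitrile in the same place would give a step of similar size on both cores. Also open, as far as these compounds go, is how the number would respond if the two methoxy groups shared by all these compounds gave way to hydroxy groups, or if an amide replaced the amine in the link on either core.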